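The compounds below may be only part of what the source reports. "The series", "measured", "known", "first", "only" and "open" are said of these compounds alone.

Measured compounds:
compound 1 `Cn1cncc1CN1CC(N(CC2CCN(C(=O)Nc3ccc(Br)cc3)CC2)S(=O)(=O)c2ccccn2)Cc2cc(C#N)ccc21` — 0.6 10^-6 cm/s
compound 2 `Cn1cncc1CN1CC(N(CC2CCN(C(=O)CC(C)(C)C)CC2)S(=O)(=O)c2ccccn2)Cc2cc(C#N)ccc21` — 0.5 10^-6 cm/s

In an ADME assay on Caco-2 cells (Homo sapiens) for permeability, in the apical to basolateral direction (a lower number here means that the compound crosses the layer more slowly, a higher number that the compound crosses the layer faster), compound 1 gives 0.6 10^-6 cm/s and compound 2 gives 0.5 10^-6 cm/s; the two sit within the scatter of each other, the step being a 1.2-fold lower number from compound 1 to compound 2 (0.08 log units; within the scatter). Compound 3 `Cn1cncc1CN1CC(N(CC2CCN(C(=O)c3ccccc3)CC2)S(=O)(=O)c2ccccn2)Cc2cc(C#N)ccc21` is not yet measured. Against compound 2 the change is phenyl in place of neopentyl on a carbonyl carbon. Among the measured compounds shown here, the only measured step, a 1.2-fold lower number from compound 1 to compound 2 (0.08 log units; within the scatter), touches the same carbonyl carbon and lay within the scatter; no step shows this particular exchange. No shift beyond the scatter is therefore expected, the estimated step being no change at the digits printed from compound 2 to compound 3 (within the scatter). For compound 3 the expected number is 0.5 10^-6 cm/s, within 0.25 10^-6 cm/s to 1.2 10^-6 cm/s.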

Compound 3, apparent permeability: 0.5 10^-6 cm/s
For compound 3 middle estimate and measured number coincide at the digits printed; low and high end bracket the measured number.
By their numbers in this assay, from the lowest: compounds 2, 3 and 1 (each within the scatter of the next).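

In this assay, exchanging neopentyl for phenyl on this carbonyl carbon stays within the scatter (no change at the digits printed from compound 2 to compound 3 (within the scatter)), as does exchanging (4-bromophenyl)amino for phenyl (a 1.2-fold lower number from compound 1 to compound 3 (0.08 log units; within the scatter)). All three groups tested at this position therefore give numbers within the scatter of one another, now including a carbon-only aromatic ring joined directly to the carbonyl. No measured evidence bears on why these numbers stay so close.

As far as these compounds go, whether an amine or a carboxylic acid on this carbonyl carbon would give a step beyond the scatter remains open. So does the effect of any exchange elsewhere on the shared core.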